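The source may hold more compounds than are shown below. What is called first, only, known or untested is meant among the compounds shown, and "the series" means these compounds.

Measured compounds:
Compound 1, `COc1cc2c(cc1C(=O)c1ccc3cc(C(=O)O)ccc3c1)C(C)(C)CCC2(C)C`, gives 53%.
Compound 2, `COc1c(C(=O)c2ccc3c(c2)C(C)(C)CCC3(C)C)ccc2cc(C(=O)O)ccc12`, gives 0%.

Both numbers come from an assay on isolated protein with retinoic acid receptor gamma (Homo sapiens) as the target; a higher number here means a larger maximal response, a lower number a smaller maximal response. Compound 2 stands lowest of the two; compound 1 lies higher by a gap that goes beyond the usual scatter of repeated measurements of this kind. Compound 3, `CC1(C)CCC(C)(C)c2cc(C(=O)c3ccc4cc(C(=O)O)ccc4c3O)ccc21`, has not yet been measured. It differs from compound 2 in one place: hydrogen in place of methyl on an oxygen on an aromatic ring. Among the measured compounds shown here, no measured pair shows this same change, so the size of its effect can only be estimated. An upward step from compound 2 to compound 3 is expected in this assay, but a modest one, because compound 2 gives 0% and only compound 1 shows that the shared core can reach a clear response at all. The expected step is a number 15 percentage points higher from compound 2 to compound 3 (beyond the scatter). Compound 3 is estimated at 15%, with a range from 0% to 50%.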

Compound 3, largest response reached (reported as maximum), in percent of the reference or control that the assay uses: 0%
For compound 3 the middle estimate is 15 percentage points above the measured one; low and high end bracket the measured number.
By their numbers in this assay, from the lowest: compounds 2 and 3 (each within the scatter of the next); then compound 1.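

In this assay, taking the methyl off this oxygen, so that methoxy becomes hydroxy, gives no change at the digits printed from compound 2 to compound 3 (within the scatter). On this core, then, neither group at this place gives a maximal response: compound 2 gives 0% and compound 3 gives 0%, so the pair cannot separate the two groups, since both sit at the bottom of the read-out. Nothing available explains this outcome.

From the compounds shown here alone, it remains open whether a longer chain on this oxygen, such as ethyl or propyl, or an amine in place of the methoxy, would give any response on this core. Going by these compounds, it also remains open what the same change from methoxy to hydroxy would do in compound 1, which gives 53%.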